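A 4-cyanophenyl in place of 2-chlorophenyl on the shared core

This account rests on a few compounds, and the source may have more. Where it says the series, first, only, none or still open, it means among the compounds named here.

Compound 2 `O=C(Cn1cc(-c2ccccc2Cl)nn1)Nc1nc2ccccc2s1` has been tested in a functional assay on BMDM cells (Mus musculus, strain C57BL/6) for inhibition, with a stated time of 2 days; a lower number here means a stronger inhibitor, a higher number a weaker inhibitor. In this assay compound 2 gives > 30000 nM, which is a limit of the assay and not a number. Compound 1 `O=C(Cn1cc(-c2ccc(F)cc2)nn1)Nc1nc2ccccc2s1` shares the core of compound 2. In this assay compound 1 gives > 30000 nM, again a limit. Within the data shown here, the one measured step, a step that the two limits leave unreadable from compound 1 to compound 2, therefore cannot be read, because both values sit at the limit of > 30000 nM in this assay, at which 2 of the 3 values shown sit. Compound 3 `O=C(Cn1cc(-c2ccc([N+](=O)[O-])cc2)nn1)Nc1nccs1` has a different core and carries a 4-nitrophenyl group. In this assay compound 3 gives 1040 nM, a number rather than a limit.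

Compound 4 `N#Cc1ccc(-c2cn(CC(=O)Nc3nc4ccccc4s3)nn2)cc1` differs from compound 2 in one place: 4-cyanophenyl in place of 2-chlorophenyl on an aromatic carbon. Among the measured compounds shown here, no measured step bears on this change, since the only step within the shared core is unreadable, and compound 3 stands on another core. What compound 3 shows is merely that a value inside the range of this assay can be reached in this series of compounds.

Resting on this thin footing, compound 4 is expected to give 12000 nM, with an estimated range from 2500 nM to 30000 nM. That estimate means a step of an at least 2.5-fold lower number from compound 2 to compound 4 (0.39 log units; beyond the scatter) from the limit of compound 2, with a real chance that the assay again reports only a limit.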

Compound 4, half-maximal inhibitory concentration: > 30000 nM
Compound 4: no number, only a limit; the forecaster's own chance of this, stated with the estimate: 45%; middle value at least 2.5-fold (0.39 log units) from the limit.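

In this assay compound 4 gives > 30000 nM, which is a limit and not a number. The steps from compound 1 and compound 2 to compound 4 cannot be read, because all three compounds sit at the same limit: the limit of > 30000 nM in this assay, at which 3 of the 4 values shown sit.

The compounds shown leave open whether any group at this place on the shared core gives a number in this assay.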